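Swapping the aryl group on the pyridazinone nitrogen

The compounds below may be only part of what the source reports. "The series", "measured", "known", "first", "only" and "open" are said of these compounds alone.

Of the compounds shown here, three sharing one core have been tested in a functional assay on A549 cells (Homo sapiens) for cytotoxicity, read by MTT assay, with a stated time of 72 h; on this read-out higher numbers stand for weaker inhibition and lower numbers for stronger inhibition. Compound 1 `Cc1cc(=O)n(-c2cccc(F)c2)nc1C(=O)Nc1ccc(Oc2ncnc3[nH]ccc23)c(F)c1` gives 31500 nM. Compound 2 `Cc1cc(=O)n(-c2cccc(F)c2)nc1C(=O)Nc1ccc(Oc2ncnc3c2ccn3C)cc1` gives 23400 nM. Compound 3 `Cc1cc(=O)n(-c2ccccc2OC(F)(F)F)nc1C(=O)Nc1ccc(Oc2ncnc3c2ccn3C)c(F)c1` reaches only the limit of the assay, > 60000 nM, so no number is known for it; it is the one compound that sits at the limit of > 60000 nM in this assay, at which 1 of the 3 values shown sits, the weakest-looking entry shown. Compound 4 `Cc1cc(=O)n(-c2cccc(F)c2)nc1C(=O)Nc1ccc(Oc2ncnc3c2ccn3C)c(F)c1` is the compound to be measured; it differs from compound 3 by 3-fluorophenyl in place of 2-(trifluoromethoxy)phenyl on an aromatic nitrogen. Compound 1 and compound 2 both carry the same 3-fluorophenyl that enters here, and both give measurable values in this assay. On that basis compound 4 is expected to move back into the measurable range, a step of an at least 2.2-fold lower number from compound 3 to compound 4 (0.34 log units; beyond the scatter) toward stronger inhibition. The estimate for compound 4 is 27000 nM, expected to fall between 10000 nM and 60000 nM.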

Compound 4, half-maximal inhibitory concentration: > 60000 nM
Compound 4 was reported as a limit; the forecaster's own chance of this, stated with the estimate: 15%; middle value at least 2.2-fold (0.34 log units) away from the limit.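

In this assay the swap on the aromatic nitrogen cannot be read, since compound 3 and compound 4 both end at a limit and not at a number: the limit of > 60000 nM in this assay, at which 2 of the 4 values shown sit.

So 3-fluorophenyl at this position does not by itself keep a compound in the measurable range. Fluoro in place of hydrogen on an aromatic carbon gives an at least 2.5-fold higher number from compound 2 to compound 4 (0.40 log units; beyond the scatter), and methyl in place of hydrogen on an aromatic nitrogen gives an at least 1.9-fold higher number from compound 1 to compound 4 (0.27 log units; that floor lies within the scatter).

As far as these compounds go, how far apart compound 3 and compound 4 truly lie stays open. So does whether a phenyl carrying an amine or a carboxylic acid at this position would give a measurable number.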